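The source may hold more compounds than are shown below. What is called first, only, known or untested is meant among the compounds shown, and "the series" means these compounds.

Among the measured compounds shown here, compound 1 `Nc1cc(N)c2nc(-c3ccccc3)c(NCc3ccc(F)cc3)nc2c1` is one of two compounds measured in a functional assay on HCT-116 cells (Homo sapiens) for inhibition, read by sulforhodamine B assay, with a stated time of 48 h; on this read-out higher numbers stand for weaker inhibition of growth and lower numbers for stronger inhibition of growth; compound 1 gives 12900 nM, the lower of the two numbers, while compound 2 `COc1ccc(CNc2nc3cc(N)cc(N)c3nc2-c2ccccc2)cc1` gives 14500 nM, a step of a 1.1-fold higher number from compound 1 to compound 2 (0.05 log units; within the scatter). Compound 3 `Nc1cc(N)c2nc(-c3ccccc3)c(Oc3ccc(F)cc3)nc2c1` differs from compound 1 by 4-fluorophenoxy in place of (4-fluorobenzyl)amino on an aromatic carbon. For the measured compounds named here, the only measured step concerns the substituent on the pendant ring, not the linker, so it does not bear on this change. He therefore expects no step beyond the scatter, a 1.2-fold higher number from compound 1 to compound 3 (0.07 log units; within the scatter), and estimates compound 3 at 15000 nM, within 5000 nM to 45000 nM in this assay.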

Compound 3, concentration for 50% growth inhibition: 14800 nM
Beside the measured number, compound 3's estimate is 1.0-fold (0.01 log units) above it, and the stated range covers the measured number.
By their numbers in this assay, from the lowest: compounds 1, 2 and 3 (each within the scatter of the next).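

In this assay, 4-fluorophenoxy in place of (4-fluorobenzyl)amino on this aromatic carbon gives a 1.1-fold higher number from compound 1 to compound 3 (0.06 log units; within the scatter). The link to the fluorinated ring can therefore change here, from an amine-bearing chain to an ether oxygen, without a step beyond the scatter, which the earlier change on the pendant ring could not show. No evidence on the reason is at hand.

The compounds shown leave open whether any group at this carbon moves the number beyond the scatter. As far as these compounds go, a sulfur link, a longer chain or a carboxylic acid there remains untested in this account.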